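The compounds below may be only part of what the source reports. "The series", "measured", "known", "first", "only" and "open" are said of these compounds alone.

Measured compounds:
compound 1 `CC(C)=CCOc1ccc2c(c1)OC(c1ccc(F)cc1)CC2=O` – 7320 nM
compound 2 `CC(C)=CCOc1cc(O)c2c(c1)OC(c1ccc(F)cc1)CC2=O` – 6060 nM

Both numbers come from a functional assay; on this read-out lower numbers stand for stronger inhibition and higher numbers for weaker inhibition. Compound 2 does not separate from compound 1 on the numbers shown. Among the compounds with values here, the only measured step, a 1.2-fold lower number from compound 1 to compound 2 (0.08 log units; within the scatter), is within the scatter, so the hydroxy group on the aromatic carbon has no resolved effect here.

Compound 3 `CC(C)=CCOc1cc(O)c2c(c1)OC(c1ccccc1Br)CC2=O` is not yet measured in this assay. It differs from compound 2 in one place: 2-bromophenyl in place of 4-fluorophenyl on a saturated ring carbon. Within the data shown here, no measured step bears on this change; the single step available concerns the hydroxy group and says nothing about exchanging 4-fluorophenyl for 2-bromophenyl on the saturated ring carbon. With nothing to lean on, the expected step of a 1.0-fold lower number from compound 2 to compound 3 (0.00 log units; within the scatter) is none beyond the scatter, and the range is kept wide. Compound 3 is therefore expected at 6000 nM in this assay, with a range from 1500 nM to 25000 nM.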

Compound 3, half-maximal inhibitory concentration: 3820 nM
Compound 3: the middle estimate sits 1.6-fold (0.20 log units) above what was measured, within the range that was stated.
By their numbers in this assay, from the lowest: compounds 3, 2 and 1 (each within the scatter of the next).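

Within this assay the first exchange at the saturated ring carbon next to the ring oxygen, 2-bromophenyl in place of 4-fluorophenyl, gives a 1.6-fold lower number from compound 2 to compound 3 (0.20 log units; within the scatter) and so has no resolved effect. On this one step, the change of halogen and of its place on the phenyl ring, at an unchanged count of heavy atoms, does not separate compound 3 from compound 2. No evidence is available that bears on this result.

Open, from the compounds shown here alone, is whether any group at this carbon moves the number beyond the scatter, for instance a phenyl ring carrying an amine or a carboxylic acid, or a cyclohexyl ring in place of the aromatic ring. Also open, going by these compounds, is how 4-bromophenyl or 2-fluorophenyl would read, as these would separate the halogen from its place on the ring.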